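Swapping the Amine Substituent: Compound 3 to Compound 4

The source may report more compounds than this note shows. Statements on the series, on what has been measured and on what is new or still open speak of the compounds shown alone.

Three compounds built on one shared core were tested in an assay on HEK293 cells for inhibition of Steryl-sulfatase (Homo sapiens), tested at 0.1 uM; a higher number here means a stronger effect of the compound at the concentration tested, a lower number a weaker effect. Compound 1 `NS(=O)(=O)Oc1ccc2c(c1)CN(C(=O)c1ccc(N3CCN(Cc4ccccc4)CC3)cc1)CC2` gives 20.8%, compound 2 `CN(C)CCCN(Cc1ccccc1)c1cccc(C(=O)N2CCc3ccc(OS(N)(=O)=O)cc3C2)c1` gives 23.8%, and compound 3 `CC(C)CCN(CCC(C)C)c1ccc(C(=O)N2CCc3ccc(OS(N)(=O)=O)cc3C2)cc1` gives 47%. Compound 3 thus stands highest of the three; its nearest neighbour is compound 2, which lies lower by a margin beyond the scatter, and compound 1 lies lower still, also beyond the scatter. Compound 4 `CCN(Cc1ccc(Br)cc1)c1ccc(C(=O)N2CCc3ccc(OS(N)(=O)=O)cc3C2)cc1` has not yet been measured. It differs from compound 3 by (4-bromobenzyl)(ethyl)amino in place of diisopentylamino on an aromatic carbon. Going by the values given here, no measured step covers this change, so an expected step downward of modest size, beyond the scatter, is assumed from compound 3 to compound 4, namely a number 17 percentage points lower from compound 3 to compound 4 (beyond the scatter). Compound 4 is therefore estimated at 30%, within 15% to 45%.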

Compound 4, a percentage reported as inhibition, at one concentration (the size of the read-out at that concentration, not a potency): 78.2%
For compound 4 the middle estimate is 48.2 percentage points below the measured one; the measured number lies above the stated range.
By their numbers in this assay, from the lowest: compounds 1 and 2 (each within the scatter of the next); then compound 3; then compound 4.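

At this position, on an aromatic carbon para to a large group, (4-bromobenzyl)(ethyl)amino in place of diisopentylamino gives a number 31.2 percentage points higher from compound 3 to compound 4 (beyond the scatter). The two groups have the same number of heavy atoms and of hydrogen-bond acceptors, so the large step comes with no change in those counts, while an aromatic ring and a bromine enter. No measurement shown here accounts for the step.

The compounds shown do not separate the contributions of the bromine, the benzyl group and the ethyl group. Going by these compounds, whether a chlorine in place of the bromine, or a propyl chain in place of the ethyl, would hold this number remains open.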